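Swapping an Allyl Group for 3-Bromobenzyl

The source may hold more compounds than are shown below. What is called first, only, known or untested is meant among the compounds shown, and "the series" means these compounds.

Three measured compounds share one core and differ only in the group on a saturated chain carbon bound to an oxygen on an aromatic ring. In a functional assay on HepG2 cells (Homo sapiens) for antiproliferative activity, read by MTT assay, with a stated time of 24 h (a lower number here means a stronger inhibitor, a higher number a weaker inhibitor), compound 1 `C=CCOc1ccc2c(=O)c(-c3cc(OC)c(OC)cc3OC)coc2c1` gives 3450 nM, the highest of the three numbers. Compound 2 `COc1cc(OC)c(-c2coc3cc(OCc4cccc(F)c4)ccc3c2=O)cc1OC` gives 1230 nM, and compound 3 `COc1cc(OC)c(-c2coc3cc(OCc4cccc(Cl)c4)ccc3c2=O)cc1OC` gives 750 nM. The steps of a 2.8-fold lower number from compound 1 to compound 2 (0.45 log units; beyond the scatter) and a 4.6-fold lower number from compound 1 to compound 3 (0.66 log units; beyond the scatter) both lie beyond the scatter, whereas a 1.6-fold lower number from compound 2 to compound 3 (0.21 log units; within the scatter) lies within it. Compound 4 `COc1cc(OC)c(-c2coc3cc(OCc4cccc(Br)c4)ccc3c2=O)cc1OC` differs from compound 1 by 3-bromophenyl in place of vinyl on a saturated chain carbon bound to an oxygen on an aromatic ring. The two earlier steps from compound 1 bear directly on this change, so a modest lowering of similar size is expected in this assay. Compound 4 is therefore expected to give 650 nM, in a range from 300 nM to 1400 nM. The expected step is a 5.3-fold lower number from compound 1 to compound 4 (0.72 log units; beyond the scatter).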

Compound 4, half-maximal inhibitory concentration: 870 nM
Beside the measured number, compound 4's estimate is 1.3-fold (0.13 log units) below it, and the stated range covers the measured number.
By their numbers in this assay, from the lowest: compounds 3, 4 and 2 (each within the scatter of the next); then compound 1.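

In this assay, the 3-bromobenzyl group also gives a step beyond the scatter, a 4.0-fold lower number from compound 1 to compound 4 (0.60 log units; beyond the scatter), so all three halogen-bearing benzyl groups now stand apart from the allyl group. The halogen itself cannot be told apart here: both bromo for chloro (a 1.2-fold higher number from compound 3 to compound 4 (0.06 log units; within the scatter)) and bromo for fluoro (a 1.4-fold lower number from compound 2 to compound 4 (0.15 log units; within the scatter)) stay within the scatter. No measured evidence explains these numbers.

Still open, from the compounds shown here alone, is whether an unsubstituted benzyl group would match these values, which would separate the effect of the ring from that of the halogen. Going by these compounds, whether an amine or a carboxylic acid on that ring would do the same is also open.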